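Swapping trifluoromethyl for methyl on the sulfonamide aryl

This account rests on a few compounds, and the source may have more. Where it says the series, first, only, none or still open, it means among the compounds named here.

The four compounds share one core. Compound 1 `O=C(NCCNc1nccc(-c2c(-c3cccc(F)c3)nc3sccn23)n1)c1c(F)cccc1F` gives 2700 nM in a functional assay on A-375 cells (Homo sapiens) for cytotoxicity, read by MTT assay; on this read-out lower numbers stand for stronger inhibition and higher numbers for weaker inhibition. Compound 2 `O=S(=O)(NCCCNc1nccc(-c2c(-c3cccc(F)c3)nc3sccn23)n1)c1ccc(C(F)(F)F)cc1` gives 4090 nM, a number close to that of compound 1 and lower than that of compound 3 `O=C(NCCNc1nccc(-c2c(-c3cccc(F)c3)nc3sccn23)n1)c1ccc(C(F)(F)F)cc1`, which gives 8710 nM. Compound 4 `Cc1ccc(S(=O)(=O)NCCCNc2nccc(-c3c(-c4cccc(F)c4)nc4sccn34)n2)cc1` is not yet measured; it differs from compound 2 by methyl in place of trifluoromethyl on an aromatic carbon. For the measured compounds named here, the only measured step that bears on this aryl substituent is a 3.2-fold higher number from compound 1 to compound 3 (0.51 log units; beyond the scatter), which exchanged the whole ring rather than one substituent on it. Going by the values given here, no measured step isolates trifluoromethyl against methyl. Compound 4 is therefore expected to show a 1.1-fold lower number from compound 2 to compound 4 (0.03 log units; within the scatter), a change not beyond the scatter. The estimate for compound 4 is 3800 nM, with a range from 1500 nM to 9500 nM.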

Compound 4, half-maximal inhibitory concentration: 8380 nM
Estimate against measurement, compound 4: 2.2-fold (0.34 log units) below; measured number inside the range.
By their numbers in this assay, from the lowest: compounds 1 and 2 (each within the scatter of the next); then compounds 4 and 3 (each within the scatter of the next).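

For the compounds shown here, the step of a 2.0-fold higher number from compound 2 to compound 4 (0.31 log units; beyond the scatter) in this assay is the first to isolate this substituent, and it shows that 4-(trifluoromethyl)phenyl and 4-methylphenyl are not interchangeable on the sulfonamide, though the difference is modest. The step of a 3.1-fold higher number from compound 1 to compound 4 (0.49 log units; beyond the scatter) changes the linking chain and the capping group together, so it cannot be assigned to either one. Nothing available accounts for the trifluoromethyl and methyl difference. From the compounds shown here alone, whether a methoxy group, a chlorine or plain hydrogen on that aromatic carbon would read closer to trifluoromethyl or to methyl remains open.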